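This account rests on a few compounds, and the source may have more. Where it says the series, first, only, none or still open, it means among the compounds named here.

Measured compounds:

Compound 1 `Cc1ccc(-c2nc(N)c3cc(Cc4ccccc4)sc3n2)o1` gives 298 nM in a functional assay on CHO-K1 cells for antagonist activity at adenosine receptor A1 (Homo sapiens), read by a beta-galactosidase reporter and cAMP accumulation, with stated times of 15 min and 6 h; on this read-out higher numbers stand for weaker inhibition and lower numbers for stronger inhibition.
Compound 2 `CCc1ccc(-c2nc(N)c3cc(Cc4ccccc4)sc3n2)o1` gives 223 nM in this assay.
Compound 3 `Nc1nc(-c2ccc(C3CC3)o2)nc2sc(Cc3ccccc3)cc12` gives 861 nM in this assay.

Compound 3 stands at the highest number of the three. The step of a 2.9-fold higher number from compound 1 to compound 3 (0.46 log units; beyond the scatter) and the step of a 3.9-fold higher number from compound 2 to compound 3 (0.59 log units; beyond the scatter) both go beyond the scatter, whereas the step of a 1.3-fold lower number from compound 1 to compound 2 (0.13 log units; within the scatter) stays within it.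

Compound 4 `N#Cc1ccc(-c2nc(N)c3cc(Cc4ccccc4)sc3n2)o1` has not yet been measured. It differs from compound 3 by cyano in place of cyclopropyl on an aromatic carbon. Among the measured compounds shown here, the only measured steps that touch this position are the two that lead to compound 3 itself, and both exchange one saturated carbon group for another; neither exchanges such a group for a cyano group, so no measured step bears directly on the change from compound 3 to compound 4. Those two steps show that the number at this position moves by a modest amount when the group on the furan changes, and that the cyclopropyl compound carries the highest number. On that basis compound 4 is expected to move off the highest number, with the step of a 1.9-fold lower number from compound 3 to compound 4 (0.28 log units; within the scatter) estimated as modest and downward, but with wide uncertainty. The estimate for compound 4 in this assay is 450 nM, within a range from 120 nM to 1800 nM.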

Compound 4, inhibition constant: 3160 nM
Estimate against measurement, compound 4: 7.0-fold (0.85 log units) below, outside the stated range (above it).
By their numbers in this assay, from the lowest: compounds 2 and 1 (each within the scatter of the next); then compound 3; then compound 4.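

In this assay, the change from 5-cyclopropylfuran-2-yl to 5-cyanofuran-2-yl raises the number rather than lowering it (a 3.7-fold higher number from compound 3 to compound 4 (0.56 log units; beyond the scatter)), so compound 4, not compound 3, now stands highest and is the weakest inhibitor of the four. Set against the two chain-bearing compounds, the cyano exchange gives the first large steps seen at this position (a 14-fold higher number from compound 2 to compound 4 (1.15 log units; beyond the scatter); an 11-fold higher number from compound 1 to compound 4 (1.03 log units; beyond the scatter)), whereas the exchanges among methyl, ethyl and cyclopropyl stayed modest or within the scatter, which shows that the number at this position can span a much wider range than those three groups revealed. Nothing available here accounts for this rise.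

On these data alone, it remains open whether the high number is particular to the cyano group or would also appear with other groups on this furan carbon, such as a chlorine atom, a methoxy group, an amide or a carboxylic acid. As far as these compounds go, it is also open whether a longer chain such as propyl or butyl would keep the number close to those of compound 1 and compound 2 or would move it towards that of compound 3.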